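This account rests on a few compounds, and the source may have more. Where it says the series, first, only, none or still open, it means among the compounds named here.

Three measured compounds share one core. In a functional assay on HL-60 cells (Homo sapiens) for antiproliferative activity, with a stated time of 24 h (a lower number here means a stronger inhibitor, a higher number a weaker inhibitor), compound 1 `N#Cc1ccccc1CN1CCc2c(sc(NC(=O)c3ccccc3Cl)c2C(N)=O)C1` gives 10400 nM. Compound 2 `NC(=O)c1c(NC(=O)c2ccc(C(F)(F)F)cc2)sc2c1CCN(Cc1c(Cl)cccc1Cl)C2` gives 10600 nM, and compound 3 `NC(=O)c1c(NC(=O)c2ccccc2F)sc2c1CCN(Cc1c(Cl)cccc1Cl)C2` gives 10300 nM. All three numbers lie within the scatter of one another, so compound 1 stands level with both. Within the data shown here, the only measured step, a 1.0-fold lower number from compound 2 to compound 3 (0.01 log units; within the scatter), changes the group on the carbonyl carbon, not the ring nitrogen. Compound 4 `NC(=O)c1c(NC(=O)c2ccccc2Cl)sc2c1CCN(C(=S)Nc1ccccc1Br)C2` differs from compound 1 at that nitrogen: a group of 10 heavy atoms (7 carbon, 1 nitrogen, 1 sulfur, 1 bromine; one six-membered aromatic ring of carbon only) in place of a group of 9 heavy atoms (8 carbon, 1 nitrogen; one six-membered aromatic ring of carbon only), on an amine nitrogen in a ring. Among the measured compounds shown here, no measured step touches this position, so no direction can be read from the data, and the three compounds with two different carbonyl groups and two different ring-nitrogen groups give the same number. Compound 4 is therefore expected to give 10000 nM, with a range from 3500 nM to 30000 nM. That estimate means a step of a 1.0-fold lower number from compound 1 to compound 4 (0.02 log units; within the scatter) which is expected to stay within the scatter.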

Compound 4, half-maximal inhibitory concentration: 9090 nM
Estimate against measurement, compound 4: 1.1-fold (0.04 log units) above, within the range that was stated.
By their numbers in this assay, from the lowest: compounds 4, 3, 1 and 2 (each within the scatter of the next).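

In this assay, among these compounds, a 1.1-fold lower number from compound 1 to compound 4 (0.06 log units; within the scatter) is the first measured step at this amine nitrogen in a ring. The entering group carries sulfur, bromine and a hydrogen-bond donor, which 2-cyanobenzyl lacks, yet the two compounds stand level. Nothing shown here offers an explanation for this.

Still open, going by these compounds, is whether a different kind of group on this nitrogen, such as a carboxylic acid or a short chain ending in an amine, would give a number beyond the scatter. On these data alone, whether the same holds with another group on the carbonyl carbon also remains unknown.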